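Trimming a methoxy group from a weak antiproliferative scaffold

The compounds below may be only part of what the source reports. "The series", "measured", "known", "first", "only" and "open" are said of these compounds alone.

Measured compounds:
- Compound 1, `COc1cccc(-n2cc(COc3ccc(/C=C/C(C)=O)cc3OC)nn2)c1`: 29600 nM
- Compound 2, `COc1cc(/C=C/C(C)=O)ccc1OCc1cn(-c2ccc(C(F)(F)F)c(C(F)(F)F)c2)nn1`: 57800 nM

Of the compounds shown here, two that share a common core have been tested in a functional assay on HCT-116 cells (Homo sapiens) for antiproliferative activity, read by MTT assay, with a stated time of 48 h; a higher number here means a weaker inhibitor, a lower number a stronger inhibitor. Compound 1 gives 29600 nM, and compound 2 gives 57800 nM. Compound 1 has the lower of the two numbers, but the gap between them lies within the scatter of repeated measurements, so the two compounds cannot be ranked against each other on this evidence. Both are weak inhibitors in this assay.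

Compound 3, `COc1cc(/C=C/C(C)=O)ccc1OCc1cn(-c2ccccc2)nn1`, has not yet been measured. It differs from compound 1 in one place: hydrogen in place of methoxy on an aromatic carbon. Put another way, a 3-methoxyphenyl group becomes a plain phenyl group.

Among the measured compounds shown here, no pair of measured compounds differing in a single place is available, so there is no direct precedent for this kind of change within this set. The loss of a small group at the edge of the molecule is expected to matter little; the step from compound 1 to compound 3 in this assay is estimated at a 1.2-fold higher number from compound 1 to compound 3 (0.07 log units; within the scatter), no larger than the scatter. Compound 3 is therefore expected to give about 35000 nM, plausibly between 12000 nM and 100000 nM.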

Compound 3, half-maximal inhibitory concentration: 67300 nM
For compound 3 the middle estimate is 1.9-fold (0.28 log units) below the measured one; low and high end bracket the measured number.
By their numbers in this assay, from the lowest: compounds 1, 2 and 3 (each within the scatter of the next, the first and the last beyond it).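

In this assay, among the compounds shown here, the change from a 3-methoxyphenyl group to a plain phenyl group gives the first comparison in this set in which only one place differs, and it reads a 2.3-fold higher number from compound 1 to compound 3 (0.36 log units; beyond the scatter). This is a modest step, but it lies beyond the scatter, so this aromatic carbon, meta to a large group, is not indifferent to what it carries: the compound with the methoxy group is the stronger inhibitor of this pair, although both remain weak. Nothing available explains why the number shifts with this change.

One pair of compounds cannot show whether the oxygen or the methyl part of the methoxy group matters, or whether the methoxy group would give the same step on another carbon of this ring. It also leaves open how a hydroxyl group, an amine, a chlorine atom or a longer chain such as ethoxy would compare with methoxy at this same place, and whether any of them would give a lower number than compound 1 does.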